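Same atoms, joined differently: from compound 2 to compound 3

The compounds below may be only part of what the source reports. "The series", "measured", "known", "first", "only" and "open" are said of these compounds alone.

Compound 1 `CC(C)Oc1cc(Oc2ccc(S(C)(=O)=O)cc2)cc(-c2cncc(=O)[nH]2)c1`: 11 mL/min/kg
Compound 2 `Cc1cnc(-c2cc(Oc3ccc(S(C)(=O)=O)cc3)cc(OC(C)C)c2)[nH]c1=O`: < 8 mL/min/kg, a limit of the assay

Both compounds were tested in an ADME assay on microsomes from liver (Homo sapiens) for metabolic stability; on this read-out higher numbers stand for fast clearance and lower numbers for slow clearance. Compound 2 gives no number, only a limit: the limit of < 8 mL/min/kg in this assay, at which 1 of the 2 values shown sits. Compound 3 `Cc1cc(=O)[nH]c(-c2cc(Oc3ccc(S(C)(=O)=O)cc3)cc(OC(C)C)c2)n1` has the same atoms as compound 2, joined differently: a group of 8 heavy atoms (5 carbon, 2 nitrogen, 1 oxygen; one six-membered aromatic ring with 2 hetero atoms) in place of a group of 8 heavy atoms (5 carbon, 2 nitrogen, 1 oxygen; one six-membered aromatic ring with 2 hetero atoms), on an aromatic carbon. The change lies on an aromatic carbon of a six-membered aromatic ring of carbon only, meta to a large group and meta to an isopropoxy group.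

Going by the values given here, one measured step bears on it, at the same place: an at least 1.3-fold lower number from compound 1 to compound 2 (0.13 log units; that floor lies within the scatter). That step is small and gives only a floor, so it is weak guidance. On that evidence, the expected step is an at least 1.1-fold higher number from compound 2 to compound 3 (0.05 log units; that floor lies within the scatter), with none expected beyond the scatter. The estimate for compound 3 is 9 mL/min/kg, with an expected range from 6 mL/min/kg to 18 mL/min/kg.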

Compound 3, clearance: < 8 mL/min/kg
Compound 3 gave a limit, no number (the forecaster's own chance of this, stated with the estimate: 40%); middle value at least 1.1-fold (0.05 log units) from the limit.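

In this assay, compound 3 also gives a limit rather than a number, so a second arrangement of the same atoms on this aromatic carbon ends at the same limit as compound 2. Measured against the group of 7 heavy atoms in compound 1, the record shows an at least 1.3-fold lower number from compound 1 to compound 3 (0.13 log units; that floor lies within the scatter), so this change, too, shows no difference beyond the scatter. The step between the two arrangements cannot be read, because both compounds sit at the limit: the limit of < 8 mL/min/kg in this assay, at which 2 of the 3 values shown sit.

The compounds shown leave open how far the true values of compound 2 and compound 3 lie past that limit, and whether the two arrangements differ at all. They also leave open how this assay would respond to a six-membered aromatic ring with 2 hetero atoms carrying an amine or a longer chain at this position.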